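The compounds below may be only part of what the source reports. "The series", "measured", "known", "first", "only" and "open" are said of these compounds alone.

Within the data shown here, compound 2 `O=C(/C=C/c1ccco1)c1ccc(NC(=O)c2ccccc2)cc1` is, in a functional assay on HCT-116 cells (Homo sapiens) for cytotoxicity, read by resazurin assay, with a stated time of 48 h (a lower number here means that less compound is needed, a higher number that more compound is needed for the effect), the higher of the two numbers measured so far: compound 2 gives 59000 nM, while compound 1 `O=C(/C=C/c1ccco1)c1ccc(NC(=O)c2cccs2)cc1` gives 45000 nM. Among the measured compounds shown here, the only step recorded between them, a 1.3-fold higher number from compound 1 to compound 2 (0.12 log units; within the scatter), exchanges the amide-side ring and stays within the scatter.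

Compound 3 `O=C(/C=C/c1ccccc1)c1ccc(NC(=O)c2ccccc2)cc1` differs from compound 2 by phenyl in place of furan-2-yl on a double-bonded chain carbon bound to a double-bonded chain carbon. For the measured compounds named here, no measured step exchanges this ring; the only step available, a 1.3-fold higher number from compound 1 to compound 2 (0.12 log units; within the scatter), concerns an aromatic ring at a different place and was small. It bears on the new change only in that a heteroaryl-to-phenyl swap elsewhere in the shared core of compound 2 left this assay essentially unchanged, so no step beyond the scatter is expected here either, with a slight lean toward a higher number.

The step from compound 2 to compound 3 is therefore expected to be a 1.1-fold higher number from compound 2 to compound 3 (0.04 log units; within the scatter). Compound 3 is estimated at 65000 nM, in the range 25000 nM to 160000 nM.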

Compound 3, half-maximal effective concentration: 28000 nM
Estimate against measurement, compound 3: 2.3-fold (0.37 log units) above, and the stated range covers the measured number.
By their numbers in this assay, from the lowest: compounds 3, 1 and 2 (each within the scatter of the next, the first and the last beyond it).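

Among these compounds, with phenyl in place of furan-2-yl on a double-bonded chain carbon bound to a double-bonded chain carbon, this assay gives the first step beyond the scatter: a 2.1-fold lower number from compound 2 to compound 3 (0.32 log units; beyond the scatter). The earlier exchange of a heteroaryl ring for phenyl, on a carbonyl carbon, stayed within the scatter at a 1.3-fold higher number from compound 1 to compound 2 (0.12 log units; within the scatter), so in these compounds the read-out responds more clearly to the ring on the chain, though the step is modest and rests on a single pair. Nothing at hand accounts for this step.

The compounds shown leave open whether the step holds with thiophen-2-yl in place of the other phenyl. They also leave open how a methoxy group or a dimethylamino group on the chain-bound phenyl would read.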